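From nitro to methanesulfonamido in the series

This account rests on a few compounds, and the source may have more. Where it says the series, first, only, none or still open, it means among the compounds named here.

In a physicochemical assay for lipophilicity, read by HPLC, measured as octanol-water partition (on this read-out higher numbers stand for higher lipophilicity and lower numbers for lower lipophilicity), compound 1 (`CCc1ccc(S(=O)(=O)NCCC[C@H]2C(=O)N(c3ccc(C)cc3)[C@@H]2c2ccc([N+](=O)[O-])cc2)cc1`) gives >= 4.4, which is a limit and not a number. Compound 2 (`Cc1ccc(N2C(=O)[C@H](CCCNS(=O)(=O)c3ccc(OC(F)(F)F)cc3)[C@H]2c2ccc([N+](=O)[O-])cc2)cc1`) gives >= 4.4, also a limit. The evidence on the measured compounds is thin: the limit of >= 4.4 in this assay, at which 2 of the 2 values shown sit. Within the data shown here, the one measured step, a step that the two limits leave unreadable from compound 1 to compound 2, has no readable size and involves different groups, so it offers no guide to the next change.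

Compound 3 (`CCc1ccc(S(=O)(=O)NCCC[C@H]2C(=O)N(c3ccc(C)cc3)[C@@H]2c2ccc(NS(C)(=O)=O)cc2)cc1`) carries methanesulfonamido in place of nitro on an aromatic carbon, para to a large group: methanesulfonamido in place of nitro on an aromatic carbon. Among the measured compounds shown here, no measured step covers this exchange, so the expectation rests on the structural change alone, and its size remains uncertain. A downward step in this assay is expected, estimated as a number at least 0.40 log units lower from compound 1 to compound 3 (beyond the scatter). For compound 3 the expected value is 4, with an estimated range of 3.4 to 4.6.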

Compound 3, partition coefficient: 3.4
Estimate against measurement, compound 3: 0.60 log units above, and the stated range covers the measured number.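

In this assay, methanesulfonamido in place of nitro on an aromatic carbon, para to a large group, gives a number at least 1.00 log units lower from compound 1 to compound 3 (beyond the scatter). This exchange moves the series off the limit, and compound 3 is the only compound shown with a number rather than a limit: the limit of >= 4.4 in this assay, at which 2 of the 3 values shown sit. The step is only a bound, since the value of compound 1 is a limit, and the entering group differs from nitro both in its hydrogen-bond donor and in its heavy atoms, which this one exchange cannot separate.

On these data alone, whether an amine or a carboxylic acid at this place would give a step of similar size remains open. So does whether the same exchange holds with trifluoromethoxy in place of ethyl, as the step between those two groups cannot be read.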